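This account rests on a few compounds, and the source may have more. Where it says the series, first, only, none or still open, it means among the compounds named here.

The measured compounds:

compound 1, `c1ccc2oc(Cn3ccnc3)cc2c1`: > 40000 nM
compound 2, `Cc1nccn1Cc1cc2ccccc2o1`: > 40000 nM

In a functional assay on SW480 cells (Homo sapiens) for cytotoxicity, read by MTT assay, with a stated time of 48 h (on this read-out higher numbers stand for weaker inhibition and lower numbers for stronger inhibition), compound 1 gives > 40000 nM, and this value is a limit of the assay rather than a number. In this assay compound 2 gives > 40000 nM, which is again a limit and not a number. The step that the two limits leave unreadable from compound 1 to compound 2 therefore cannot be sized, because both values sit at the limit of > 40000 nM in this assay, at which 2 of the 2 values shown sit. On the numbers shown, compound 2 stands only at a limit, with no measured value that places it any more precisely.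

Compound 3, `CCc1nccn1Cc1cc2ccccc2o1`, is the next compound to be measured in this assay. It differs from compound 2 by methyl in place of hydrogen on a saturated chain carbon bound to an aromatic carbon. Within the data shown here, the only measured step that bears on it, a step that the two limits leave unreadable from compound 1 to compound 2, is the earlier addition of a methyl group and remained unreadable between the two limits, so no size or direction can be taken from it. With nothing to suggest a step beyond the scatter, compound 3 is expected to give 60000 nM, within a range of 20000 nM to 200000 nM. The step that the limit leaves unreadable from compound 2 to compound 3 is thus estimated to be none beyond the scatter, most likely ending at the same limit.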

Compound 3, half-maximal inhibitory concentration: > 40000 nM
Compound 3 was reported as a limit; the forecaster's own chance of this, stated with the estimate: 85%; the middle value lies beyond the limit too.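

In this assay compound 3 gives > 40000 nM, which is a limit and not a number. Among these compounds, no step among compound 1, compound 2 and compound 3 can therefore be read: the limit of > 40000 nM in this assay, at which 3 of the 3 values shown sit. The compounds shown leave open whether methyl or ethyl in place of hydrogen changes the cytotoxicity at all, and by how much.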